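The source may report more compounds than this note shows. Statements on the series, on what has been measured and on what is new or still open speak of the compounds shown alone.

Three measured compounds share one core and differ only in the group on the ring amine nitrogen. Compound 1 `N#Cc1cccc(COc2ccc(-c3cc(CN4CCN(c5ccc(C(F)(F)F)cn5)CC4)no3)cc2)c1` gives 1300 nM in a functional assay on Mahlavu cells (Homo sapiens) for antiproliferative activity, read by sulforhodamine B assay, with a stated time of 72 h; a higher number here means a weaker inhibitor, a lower number a stronger inhibitor. Compound 2 `N#Cc1cccc(COc2ccc(-c3cc(CN4CCN(c5ccc(F)cc5)CC4)no3)cc2)c1` gives 2200 nM in this assay, and compound 3 `N#Cc1cccc(COc2ccc(-c3cc(CN4CCN(Cc5ccc(F)cc5)CC4)no3)cc2)c1` gives 1500 nM. All three numbers sit close together: a 1.7-fold higher number from compound 1 to compound 2 (0.23 log units; within the scatter), a 1.2-fold higher number from compound 1 to compound 3 (0.06 log units; within the scatter), and a 1.5-fold lower number from compound 2 to compound 3 (0.17 log units; within the scatter), so compound 3 stands among values that cannot be ordered.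

Compound 4 `N#Cc1cccc(COc2ccc(-c3cc(CN4CCN(Cc5ccccc5F)CC4)no3)cc2)c1` is not yet measured. Relative to compound 3 the change is 2-fluorophenyl in place of 4-fluorophenyl on a saturated chain carbon bound to an amine nitrogen in a ring. For the measured compounds named here, no measured step moves the fluorine around the benzyl ring; the steps on record exchange the whole group on the amine nitrogen, and every one of them stays within the scatter. Nothing in the series therefore points to a shift in either direction, and the step from compound 3 to compound 4 is expected to be no change at the digits printed from compound 3 to compound 4 (within the scatter), that is, no change beyond the scatter. Compound 4 is estimated at 1500 nM, with a range from 700 nM to 3500 nM.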

Compound 4, half-maximal inhibitory concentration: 2300 nM
For compound 4 the middle estimate is 1.5-fold (0.19 log units) below the measured one; low and high end bracket the measured number.
By their numbers in this assay, from the lowest: compounds 1, 3, 2 and 4 (each within the scatter of the next).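

Moving the fluorine around the benzyl ring, on a saturated chain carbon bound to an amine nitrogen in a ring, now has a reading of its own in this assay (a 1.5-fold higher number from compound 3 to compound 4 (0.19 log units; within the scatter)), and this change stays inside the scatter. The exchanges of the whole group that lead to 2-fluorobenzyl read the same way (a 1.0-fold higher number from compound 2 to compound 4 (0.02 log units; within the scatter)) and (a 1.8-fold higher number from compound 1 to compound 4 (0.25 log units; within the scatter)), so all four groups on the amine nitrogen remain in one unordered band. No separate data bear on this result.

Going by these compounds, whether a phenethyl or a 4-carboxybenzyl group on the amine nitrogen would give a step beyond the scatter remains open. All four compounds share one core, so the effect of a change elsewhere on it is also unresolved.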